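A few compounds are considered here, and "the series" means these few. Any claim that something is new, unique, unknown or untested is made for them only; others in the source may bear on it.

Values so far in an ADME assay (liver) for metabolic stability, with Liver microsome (Homo sapiens) as the target, using microsomes and NADPH, with a stated time of 30 min, tested at 1 uM (a higher number here means faster removal of the compound, a lower number slower removal), are these:
- compound 1 `CC(C)n1cc(-c2cc(C(O)(C(F)(F)F)C(F)(F)F)cnc2N2CCN(S(=O)(=O)c3ccc(N)nc3)CC2)cn1` gives 38 mL.min-1.g-1
- compound 2 `NC(=O)c1cccc(-c2cc(C(O)(C(F)(F)F)C(F)(F)F)cnc2N2CCN(S(=O)(=O)c3ccc(N)nc3)CC2)c1` gives 17 mL.min-1.g-1

Compound 2 stands lowest of the two. Compound 3 `Nc1ccc(S(=O)(=O)N2CCN(c3ncc(C(O)(C(F)(F)F)C(F)(F)F)cc3-c3ccncc3)CC2)cn1` differs from compound 2 at one place, with pyridin-4-yl in place of 3-carbamoylphenyl on an aromatic carbon. For the measured compounds named here, one measured step bears on this place (a 2.2-fold lower number from compound 1 to compound 2 (0.35 log units; beyond the scatter)). Going by the values given here, it is modest and involves a different incoming group, and pyridin-4-yl itself has no measurement yet. In this assay a smaller, slightly upward step is therefore expected, possibly inside the scatter. The estimated step is small (a 1.3-fold higher number from compound 2 to compound 3 (0.11 log units; within the scatter)). Compound 3 is estimated at 22 mL.min-1.g-1 within an expected range (10 mL.min-1.g-1 to 45 mL.min-1.g-1).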

Compound 3, intrinsic clearance in microsomes: 15 mL.min-1.g-1
Compound 3: middle estimate off by 1.5-fold (0.17 log units), on the high side; the measured number falls inside the stated range.
By their numbers in this assay, from the lowest: compounds 3 and 2 (each within the scatter of the next); then compound 1.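

In this assay, pyridin-4-yl can stand on this aromatic carbon in place of 3-carbamoylphenyl with no reading beyond the scatter (a 1.1-fold lower number from compound 2 to compound 3 (0.05 log units; within the scatter)), so the amide is not needed for a number at this level. A second six-membered aromatic ring also lies below the pyrazole compound (a 2.5-fold lower number from compound 1 to compound 3 (0.40 log units; beyond the scatter)), and no compound shown goes against this. Nothing available explains the result.

From the compounds shown here alone, whether the pyrazole ring or its isopropyl group carries the difference remains open, and 1-methyl-1H-pyrazol-4-yl would separate the two. A carboxylic acid or an aminomethyl group on the phenyl ring is also untested among these compounds.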